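The source may report more compounds than this note shows. Statements on the series, on what has been measured and on what is new or still open speak of the compounds shown alone.

For the measured compounds named here, in a functional assay on HT-1080 cells (Homo sapiens) for cytotoxicity, read by MTT assay, with a stated time of 72 h (on this read-out lower numbers stand for stronger inhibition and higher numbers for weaker inhibition), compound 1 (`COc1cccc(/C=C2\CCC/C(=C\c3cccc(Br)c3)C2=O)c1OC`) gives 12200 nM and compound 2 (`COc1cc(/C=C2\CCC/C(=C\c3cccc(OC)c3OC)C2=O)ccc1O`) gives 5900 nM, so compound 2 holds the lower of the two numbers so far. Compound 3 (`COc1cccc(/C=C2\CCC/C(=C\c3ccc(O)c(O)c3)C2=O)c1OC`) has not yet been measured. It differs from compound 2 as follows: hydrogen in place of methyl on an oxygen on an aromatic ring. This places hydrogen in place of methyl on an oxygen on an aromatic ring, turning 4-hydroxy-3-methoxyphenyl into 3,4-dihydroxyphenyl. Going by the values given here, only one measured step bears on this change: a 2.1-fold lower number from compound 1 to compound 2 (0.32 log units; beyond the scatter). That modest step introduced the 4-hydroxy-3-methoxyphenyl group that now changes again, but it exchanged a different group and offers only a weak guide. A small move toward a lower number is therefore expected, and the estimated step, a 1.5-fold lower number from compound 2 to compound 3 (0.17 log units; within the scatter), may stay within the scatter. Compound 3 is expected at about 4000 nM, with an estimated range of 1500 nM to 10000 nM.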

Compound 3, half-maximal inhibitory concentration: 4700 nM
Estimate against measurement, compound 3: 1.2-fold (0.07 log units) below; the measured number falls inside the stated range.
By their numbers in this assay, from the lowest: compounds 3 and 2 (each within the scatter of the next); then compound 1.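

In this assay the change from methoxy to hydroxy, which turns 4-hydroxy-3-methoxyphenyl into 3,4-dihydroxyphenyl, gives a 1.3-fold lower number from compound 2 to compound 3 (0.10 log units; within the scatter) and so does not separate these two compounds at this position. Against 3-bromophenyl, the 3,4-dihydroxyphenyl group gives a 2.6-fold lower number from compound 1 to compound 3 (0.41 log units; beyond the scatter) in this same read-out, so both groups carrying two oxygens on the aromatic ring stand apart from the bromine-bearing compound 1, while the methyl on that oxygen makes no difference that can be read. Nothing measured here gives a reason for either step.

From the compounds shown here alone, it remains open whether an amine or a carboxylic acid in place of the hydroxy would move the number beyond the scatter. A longer chain on the oxygen, such as ethoxy in place of methoxy, is equally untested by the compounds shown.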